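Moving the Chlorine on the Enone Ring of Compound 1

A few compounds are considered here, and "the series" means these few. Any claim that something is new, unique, unknown or untested is made for them only; others in the source may bear on it.

Among the compounds with values here, compound 1 `Cc1cccc(Nc2nc(C)c(C(=O)/C=C/c3ccccc3Cl)s2)c1` is one of two compounds measured in a functional assay on BGC-823 cells (Homo sapiens) for cytotoxicity, read by MTT assay (a higher number here means a weaker inhibitor, a lower number a stronger inhibitor), and in this assay compound 1 gives 24200 nM. Compound 2 `Cc1ccccc1Nc1nc(C)c(C(=O)/C=C/c2ccccc2Cl)s1` differs from it only in where the methyl sits on the aniline ring, and compound 2 gives only a limit of the assay, > 25000 nM, not a number. The step of an at least 1.0-fold higher number from compound 1 to compound 2 (0.01 log units; that floor lies within the scatter) can thus be sized only at its floor, which is what the limit of > 25000 nM in this assay, at which 1 of the 2 values shown sits, records. Compound 3 `Cc1cccc(Nc2nc(C)c(C(=O)/C=C/c3ccc(Cl)cc3)s2)c1` differs from compound 1 elsewhere: 4-chlorophenyl in place of 2-chlorophenyl on a double-bonded chain carbon bound to a double-bonded chain carbon. Within the data shown here, no measured step touches this chlorine-bearing ring, and the single step that is measured concerns the other ring and stays within the scatter. With nothing measured pointing either way, the expected step of a 1.0-fold lower number from compound 1 to compound 3 (0.00 log units; within the scatter) is one within the scatter. Compound 3 is therefore estimated to give about 24000 nM in this assay, with a range from 8000 nM to 70000 nM.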

Compound 3, half-maximal inhibitory concentration: > 25000 nM
Compound 3: only a limit was reported; the forecaster's own chance of this, stated with the estimate: 40%; at least 1.0-fold (0.01 log units) between middle value and limit.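

In this assay compound 3 gives > 25000 nM, which is a limit of the assay and not a number. Within the data shown here, this is the first measured change on the chlorine-bearing ring, and 4-chlorophenyl in place of 2-chlorophenyl gives an at least 1.0-fold higher number from compound 1 to compound 3 (0.01 log units; that floor lies within the scatter), so moving the chlorine shows no change that can be told from the scatter, though a larger one is not ruled out. The step can be sized only at its floor because most of the values stand at the limit of the assay: the limit of > 25000 nM in this assay, at which 2 of the 3 values shown sit.

As far as these compounds go, how far compound 3 truly lies from compound 1 therefore stays open, and with it whether the place of the chlorine matters at all in this assay. Also open, from the compounds shown here alone, is what a methoxy group or an amine would give in place of the chlorine on this ring.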